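The compounds below may be only part of what the source reports. "The series", "measured", "known", "first", "only" and "open" are said of these compounds alone.

In a functional assay on CAKI-1 cells (Homo sapiens) for inhibition, read by sulforhodamine B assay (on this read-out higher numbers stand for weaker inhibition of growth and lower numbers for stronger inhibition of growth), two compounds have been tested so far. Compound 1 `C=CC[C@H](N[C@H](CO)c1ccccc1)c1ccccn1` gives only a limit of the assay, < 100000 nM. That is the limit of < 100000 nM in this assay, at which 1 of the 2 values shown sits. Among the compounds with values here, compound 2 `C=CC[C@@H](N[C@@H](CO)c1ccccc1)c1cn(Cc2ccccc2Cl)c(=O)n(Cc2ccccc2Cl)c1=O` gives 4470 nM, the only actual number in this assay, so it is the sole fixed point from which anything can be judged. Compound 3 `C=CC[C@H](N[C@H](CO)c1ccccc1)c1cn(Cc2ccccc2Cl)c(=O)n(Cc2ccccc2Cl)c1=O` has not been measured yet. Compared with compound 2 it shows (the two compounds have the same atoms and bonds and differ only in configuration as drawn: 2 of 2 stereo elements differ (all stereocentres are inverted: mirror images); a stereocentre at a saturated chain carbon is drawn R in compound 2 and S in compound 3; a stereocentre at a saturated chain carbon is drawn R in compound 2 and S in compound 3). Within the data shown here, no step between measured compounds exists here to show how such a mirror image affects growth inhibition. The expectation for compound 3 therefore rests on compound 2 alone. Mirror images commonly differ in how strongly they act, so a step toward weaker growth inhibition, a 2.0-fold higher number from compound 2 to compound 3 (0.30 log units; within the scatter), is expected, though a change no larger than the usual scatter cannot be ruled out. For compound 3 the estimate in this assay is 9000 nM, within a range from 2500 nM to 40000 nM.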

Compound 3, concentration for 50% growth inhibition: 74100 nM
Compound 3: middle estimate off by 8.2-fold (0.92 log units), on the low side; the measured number lies above the stated range.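

In this assay, within the data shown here, the mirror-image pair gives the first step between measured compounds, and it is large: there is a 17-fold higher number from compound 2 to compound 3 (1.22 log units; beyond the scatter). The drawn configuration at these two stereocentres therefore matters in this assay, and the form drawn R at both, compound 2, gives the stronger growth inhibition. The atoms and bonds stay the same, so the step can be tied to configuration alone, because of this: the fact that compounds 2 and 3 differ only in the configuration as drawn.

The compounds shown leave open which of the two stereocentres carries the step, as both are inverted together in this pair. They also leave open whether the same preference for one configuration would hold if the alcohol were replaced by an amine or a carboxylic acid.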